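Moving Two Methyl Groups Around the Amide Aryl Ring

The source may hold more compounds than are shown below. What is called first, only, known or untested is meant among the compounds shown, and "the series" means these compounds.

Compound 1 `COc1ccc(NC(=O)/C=C/C(=O)N2C/C(=C\c3ccc([N+](=O)[O-])cc3)C(=O)/C(=C/c3ccc([N+](=O)[O-])cc3)C2)cc1` gives 760 nM in a functional assay on CCRF-CEM cells (Homo sapiens) for cytotoxicity; on this read-out higher numbers stand for weaker inhibition and lower numbers for stronger inhibition.
Compound 2 `O=C(/C=C/C(=O)N1C/C(=C\c2ccc([N+](=O)[O-])cc2)C(=O)/C(=C/c2ccc([N+](=O)[O-])cc2)C1)Nc1ccc([N+](=O)[O-])cc1` gives 410 nM in this assay.
Compound 3 `Cc1ccc(NC(=O)/C=C/C(=O)N2C/C(=C\c3ccc([N+](=O)[O-])cc3)C(=O)/C(=C/c3ccc([N+](=O)[O-])cc3)C2)cc1C` gives 700 nM in this assay.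

All three share one core and differ only in the aryl group on the amide nitrogen. On the numbers shown, compound 3 stands second highest of three, yet every step among the pairs is within the scatter: a 1.1-fold lower number from compound 1 to compound 3 (0.04 log units; within the scatter), a 1.7-fold higher number from compound 2 to compound 3 (0.23 log units; within the scatter) and a 1.9-fold lower number from compound 1 to compound 2 (0.27 log units; within the scatter). Compound 4 `Cc1cccc(C)c1NC(=O)/C=C/C(=O)N1C/C(=C\c2ccc([N+](=O)[O-])cc2)C(=O)/C(=C/c2ccc([N+](=O)[O-])cc2)C1` is not yet measured; it differs from compound 3 by 2,6-dimethylphenyl in place of 3,4-dimethylphenyl on an amide-type nitrogen. For the measured compounds named here, no measured pair moves methyl groups around the same ring, so none bears on this change directly; the measured steps only show that exchanging the aryl group has so far left this assay within the scatter. The expected step is therefore no change at the digits printed from compound 3 to compound 4 (within the scatter), none beyond the scatter. Compound 4 is estimated at 700 nM, with a range of 300 nM to 1600 nM.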

Compound 4, half-maximal inhibitory concentration: 230 nM
Beside the measured number, compound 4's estimate is 3.0-fold (0.48 log units) above it, outside the stated range (below it).
By their numbers in this assay, from the lowest: compounds 4, 2, 3 and 1 (each within the scatter of the next, the first and the last beyond it).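

Rearranging the same two methyl groups on the aryl ring attached to the amide nitrogen is enough to shift the read-out in this assay: the change to 2,6-dimethylphenyl gives a 3.0-fold lower number from compound 3 to compound 4 (0.48 log units; beyond the scatter) and, against the methoxy analogue, a 3.3-fold lower number from compound 1 to compound 4 (0.52 log units; beyond the scatter), the first steps in this set beyond the scatter. The 4-nitrophenyl analogue stays close, with a 1.8-fold lower number from compound 2 to compound 4 (0.25 log units; within the scatter), so these two cannot be ranked. Nothing available explains the shift. Still open, from the compounds shown here alone, is whether both methyl groups are needed, and whether ethyl groups, chlorine atoms or an amine on the ring would give a similar number.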